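Moving the chloro around the phenyl: toward compound 4

The compounds below may be only part of what the source reports. "The series", "measured", "known", "first", "only" and "open" are said of these compounds alone.

Compound 1 `O=C(CN1CCN(c2cc3c(cc2F)c(=O)c(C(=O)O)cn3C2CC2)CC1)Nc1ccc(C(=O)/C=C/c2ccccc2)cc1`: 57.2%
Compound 2 `O=C(CN1CCN(c2cc3c(cc2F)c(=O)c(C(=O)O)cn3C2CC2)CC1)Nc1ccc(C(=O)/C=C/c2ccccc2Cl)cc1`: 70.8%
Compound 3 `O=C(CN1CCN(c2cc3c(cc2F)c(=O)c(C(=O)O)cn3C2CC2)CC1)Nc1ccc(C(=O)/C=C/c2cccc(Cl)c2)cc1`: 68.8%

All values come from an assay on isolated protein for inhibition of DNA topoisomerase 1 (Homo sapiens), with a stated time of 30 min, tested at 100 uM; on this read-out lower numbers stand for a weaker effect and higher numbers for a stronger effect at the one concentration tested. Compound 3 stands second highest of the three numbers; its nearest neighbour is compound 2, and the gap a number 2 percentage points lower from compound 2 to compound 3 (within the scatter) lies within the scatter, while the gap to compound 1, a number 11.6 percentage points higher from compound 1 to compound 3 (beyond the scatter), lies beyond it. Compound 4 `O=C(CN1CCN(c2cc3c(cc2F)c(=O)c(C(=O)O)cn3C2CC2)CC1)Nc1ccc(C(=O)/C=C/c2ccc(Cl)cc2)cc1` differs from compound 3 by 4-chlorophenyl in place of 3-chlorophenyl on a double-bonded chain carbon bound to a double-bonded chain carbon. Both chloro placements examined so far raised the number over the parent without chloro: a number 13.6 percentage points higher from compound 1 to compound 2 (beyond the scatter) and a number 11.6 percentage points higher from compound 1 to compound 3 (beyond the scatter) are of similar size, and the two chloro isomers are separated only within the scatter, a number 2 percentage points lower from compound 2 to compound 3 (within the scatter). For the measured compounds named here, no measured step tests the 4-chlorophenyl itself, so the step of a number 0.8 percentage points lower from compound 3 to compound 4 (within the scatter) is expected to be small and within the scatter. Compound 4 is therefore estimated at 68%, in a range from 56% to 80%.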

Compound 4, a percentage reported as inhibition, at one concentration (the size of the read-out at that concentration, not a potency): 67.5%
Compound 4: middle estimate off by 0.5 percentage points, on the high side; the range from low to high includes it.
By their numbers in this assay, from the lowest: compound 1; then compounds 4, 3 and 2 (each within the scatter of the next).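

With a number 1.3 percentage points lower from compound 3 to compound 4 (within the scatter) and a number 3.3 percentage points lower from compound 2 to compound 4 (within the scatter) the three chlorophenyl isomers on this double-bonded chain carbon cannot be told apart, so this read-out shows no preference for where the chloro sits. The rise over the phenyl without chloro also holds for 4-chlorophenyl, with a number 10.3 percentage points higher from compound 1 to compound 4 (beyond the scatter) just as for the other two isomers. No evidence is at hand on what lies behind these numbers. Open, from the compounds shown here alone, is whether a methoxy, an amine or a carboxylic acid in place of the chloro gives a similar number, and whether a second chloro on the same phenyl changes it.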